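Aryl-amino replacing benzyl(methyl)amino on the shared core

The source may report more compounds than this note shows. Statements on the series, on what has been measured and on what is new or still open speak of the compounds shown alone.

Working notes on the series. Compound 1 `Cc1cc(Nc2ccc(F)cc2)nc(SCc2nc3ccccc3[nH]2)n1` in a functional assay on PC-3 cells (Homo sapiens) for cytotoxicity, read by MTT assay, with a stated time of 72 h (on this read-out lower numbers stand for stronger inhibition and higher numbers for weaker inhibition), gives 56200 nM. Compound 2 `Cc1cc(NNC(N)=S)nc(SCc2nc3ccccc3[nH]2)n1` is reported in this assay only as the limit > 100000 nM. Compound 3 `Cc1cc(N(C)Cc2ccccc2)nc(SCc2nc3ccccc3[nH]2)n1` likewise stands in this assay only at the limit > 100000 nM. Compound 3 thus has no number of its own; the limit of > 100000 nM in this assay, at which 2 of the 3 values shown sit, marks where two of the three values sit, and the pair of limits leaves the step that the two limits leave unreadable from compound 2 to compound 3 unreadable.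

Compound 4 `Cc1cc(Nc2ccc(Cl)cc2)nc(SCc2nc3ccccc3[nH]2)n1` differs from compound 3 by (4-chlorophenyl)amino in place of benzyl(methyl)amino on an aromatic carbon. The measured step that bears on this change is the one in the opposite direction, an at least 1.7-fold higher number from compound 1 to compound 3 (0.25 log units; that floor lies within the scatter), which took an arylamino compound with a number onto the limit; the step of an at least 1.7-fold higher number from compound 1 to compound 2 (0.25 log units; that floor lies within the scatter) concerns a different group and bears on it less. Reversing that change is expected to bring the number back off the limit, into the region of compound 1, so the step of an at least 2.5-fold lower number from compound 3 to compound 4 (0.39 log units; beyond the scatter) is expected. Compound 4 is therefore estimated at 40000 nM, within 15000 nM to 100000 nM, with a real chance that this assay again reports only a limit.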

Compound 4, half-maximal inhibitory concentration: 36000 nM
The estimate for compound 4 lay 1.1-fold (0.05 log units) above the measured number; low and high end bracket the measured number.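

On this aromatic carbon, (4-chlorophenyl)amino in place of benzyl(methyl)amino gives a step in this assay that can be read as beyond the scatter, an at least 2.7-fold lower number from compound 3 to compound 4 (0.44 log units; beyond the scatter), whereas the floor of the earlier step from an arylamino compound to compound 3 lay within it; the group on the nitrogen gives a similar reading, an at least 2.7-fold lower number from compound 2 to compound 4 (0.44 log units; beyond the scatter). The halogen exchange on the aryl ring separates the two arylamino compounds by no more than the scatter, a 1.6-fold lower number from compound 1 to compound 4 (0.19 log units; within the scatter). Only compound 1 and compound 4, both arylamino, carry numbers in this assay, while compound 2 and compound 3 stand at a limit of the assay: the limit of > 100000 nM in this assay, at which 2 of the 4 values shown sit.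

The change from compound 3 to compound 4 alters the amine nitrogen, the link to the ring and the ring substituent together, so the compounds shown do not tell which of these carries the step. From the compounds shown here alone, whether benzylamino without the methyl, or phenylamino without a halogen, would also give a number rather than a limit in this assay stays open.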